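The source may report more compounds than this note shows. Statements on the series, on what has been measured and on what is new or still open speak of the compounds shown alone.

Measured so far:
- Compound 1 `C[C@H](NC(=O)C(=O)NCCC1CCCC1)C(=O)N[C@@H](CC(=O)O)C(=O)COc1c(F)c(F)cc(F)c1F`: 11 nM
- Compound 2 `C[C@H](NC(=O)C(=O)NCc1ccc(F)cc1)C(=O)N[C@@H](CC(=O)O)C(=O)COc1c(F)c(F)cc(F)c1F`: 197 nM
- Compound 3 `Cc1ccc(CNC(=O)C(=O)N[C@@H](C)C(=O)N[C@@H](CC(=O)O)C(=O)COc2c(F)c(F)cc(F)c2F)c(C)c1`: > 10000 nM

These values come from a functional assay on Jurkat cells (Homo sapiens); a lower number here means a stronger inhibitor, a higher number a weaker inhibitor.

The entry for compound 3 in this assay is > 10000 nM. That entry is a limit of the assay and not a number.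

Compound 4 `Cc1ccc(C)c(CNC(=O)C(=O)N[C@@H](C)C(=O)N[C@@H](CC(=O)O)C(=O)COc2c(F)c(F)cc(F)c2F)c1` has the same atoms as compound 3, joined differently: 2,5-dimethylphenyl in place of 2,4-dimethylphenyl on a saturated chain carbon bound to an amide-type nitrogen. Here 2,5-dimethylphenyl takes the place of 2,4-dimethylphenyl on a saturated chain carbon bound to an amide-type nitrogen.

Three measured steps change this same place, and all are large: an 18-fold higher number from compound 1 to compound 2 (1.25 log units; beyond the scatter), an at least 900-fold higher number from compound 1 to compound 3 (2.95 log units; beyond the scatter) and an at least 50-fold higher number from compound 2 to compound 3 (1.70 log units; beyond the scatter). For the measured compounds named here, the values therefore respond strongly to this group, but no measured step compares two dimethylphenyl groups. The two isomers are expected to stay close, with compound 4 remaining weak and possibly at the limit again, though a wide range is needed.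

The expected change is an at least 2.0-fold lower number from compound 3 to compound 4 (0.30 log units; that floor lies within the scatter).

Compound 4 is estimated at 5000 nM, with an expected range from 400 nM to 20000 nM.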

Compound 4, half-maximal inhibitory concentration: 11 nM
Beside the measured number, compound 4's estimate is 450-fold (2.66 log units) above it; measured number outside the range, below it.
By their numbers in this assay, from the lowest: compounds 1 and 4 (each within the scatter of the next); then compound 2. At a limit, above all of these: compound 3.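

In this assay, for the compounds shown here, 2,5-dimethylphenyl in place of 2,4-dimethylphenyl gives an at least 900-fold lower number from compound 3 to compound 4 (2.95 log units; beyond the scatter), showing that this position can separate two isomers built from the same atoms, which no earlier step could show. Compound 3 stands at a limit of the assay and not at a number, so the size of this step is only a floor: the limit of > 10000 nM in this assay, at which 1 of the 4 values shown sits. An aromatic group here can also match the saturated one: 2,5-dimethylphenyl gives an 18-fold lower number from compound 2 to compound 4 (1.25 log units; beyond the scatter) against 4-fluorophenyl and no change at the digits printed from compound 1 to compound 4 (within the scatter) against cyclopentylmethyl, so compounds 2 and 3 did not set a general rule for aromatic groups at this place.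

From the compounds shown here alone, whether a 2-methylphenyl, a 3-methylphenyl or a 2,5-dichlorophenyl group would hold the level of compound 4 remains open. So does the effect of a longer chain between this ring and the amide-type nitrogen.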